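The compounds below may be only part of what the source reports. "The series", "measured", "known", "first", "only" and "open" are said of these compounds alone.

Measured compounds:
- compound 1 `CCOc1ccc2[nH]c(-c3ccccc3)c(C3=C(Br)C(=O)NC3=O)c2c1` — 2.77
- compound 2 `CCCOc1ccc2[nH]c(-c3ccccc3)c(C3=C(Br)C(=O)NC3=O)c2c1` — 3.16
- compound 3 `CCCOc1ccc2[nH]c(-c3ccc(OC)cc3)c(C3=C(Br)C(=O)NC3=O)c2c1` — 3.12

In a physicochemical assay for lipophilicity (a higher number here means a more lipophilic compound, a lower number a more polar compound), compound 3 gives 3.12. Compound 2 sits with it within the scatter, as a number 0.04 log units lower from compound 2 to compound 3 (within the scatter) shows; compound 1, at 2.77, lies further off, and that gap is beyond the scatter.

Compound 4 `CCCCCc1ccc2[nH]c(-c3ccc(OC)cc3)c(C3=C(Br)C(=O)NC3=O)c2c1` is not yet measured. It differs from compound 3 in one place: pentyl in place of propoxy on an aromatic carbon. Of the measured steps, a number 0.39 log units higher from compound 1 to compound 2 (beyond the scatter) is the one that bears on a change in chain length on the same part of the core, and it was modest. a number 0.04 log units lower from compound 2 to compound 3 (within the scatter) concerns the methoxy on the other aromatic ring and says nothing direct about this position. Going by the values given here, no measured pair swaps an ether for a plain alkyl chain, so that part of the change rests on general expectation only. Taken together, a step clearly beyond the scatter and upward is expected, a number 1.28 log units higher from compound 3 to compound 4 (beyond the scatter). Compound 4 is therefore estimated at 4.4, with a range of 3.9 to 4.9.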

Compound 4, partition coefficient: 4.1
Compound 4: middle estimate off by 0.30 log units, on the high side, and the stated range covers the measured number.
By their numbers in this assay, from the lowest: compound 1; then compounds 3 and 2 (each within the scatter of the next); then compound 4.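

In this assay, pentyl in place of propoxy on an aromatic carbon gives a number 0.98 log units higher from compound 3 to compound 4 (beyond the scatter), a larger step than a number 0.39 log units higher from compound 1 to compound 2 (beyond the scatter) seen when the ether chain grew at this same position. The new step is the only one shown in which the ether oxygen leaves, taking the hydrogen-bond acceptor counted in propoxy with it, and the chain changes length in that same step, so the two parts of the change cannot be separated here. Nothing measured in the series gives a reason for the size of this step.

On these data alone, a propyl chain at this position would separate the loss of the oxygen from the added length, and it remains open whether it would sit nearer compound 3 or compound 4. As far as these compounds go, how a longer chain, or an amine in place of the chain, would read at this position also remains open.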